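The source may report more compounds than this note shows. Statements on the series, on what has been measured and on what is new or still open speak of the compounds shown alone.

Compound 1 `CCCCCCCOc1cccc(C[C@H]2C(=O)OC[C@@H]2Cc2ccccc2)c1`, compound 2 `Cc1cccc(C[C@H]2C(=O)OC[C@@H]2Cc2ccccc2)c1` and compound 3 `CCCCCCCOc1ccc(C[C@H]2C(=O)OC[C@@H]2Cc2ccccc2)cc1` share a core; how the core of compound 1 and that of compound 3 differ is not broken down here. In a functional assay on HL-60 cells (Homo sapiens) for cytotoxicity, read by WST assay, with a stated time of 48 h (a higher number here means that more compound is needed for the effect, a lower number that less compound is needed), compound 1 gives 81000 nM, and compound 2 gives 53000 nM, so the change methyl in place of heptyloxy on an aromatic carbon made a 1.5-fold lower number from compound 1 to compound 2 (0.18 log units; within the scatter). For compound 3 the value in this assay is a limit rather than a number: compound 3 gives > 100000 nM, as stated in the limit of > 100000 nM in this assay, at which 1 of the 3 values shown sits. Compound 4 `Cc1ccc(C[C@H]2C(=O)OC[C@@H]2Cc2ccccc2)cc1` is not yet measured. Its change from compound 3, (methyl in place of heptyloxy on an aromatic carbon), is the same kind of change as that from compound 1 to compound 2, but the place differs: meta to a large group in the first pair, para to a large group in the second. Because compound 1 to compound 2 gave a 1.5-fold lower number from compound 1 to compound 2 (0.18 log units; within the scatter), the step from compound 3 to compound 4 is expected to be a step that the limit leaves unreadable from compound 3 to compound 4. Compound 4 is therefore estimated at 110000 nM in this assay.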

Compound 4, half-maximal effective concentration: 44000 nM
Compound 4: middle estimate off by 2.5-fold (0.40 log units), on the high side, outside the stated range (below it).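

In this assay, methyl in place of heptyloxy gave an at least 2.2-fold lower number from compound 3 to compound 4 (0.35 log units; beyond the scatter), and 4-methylphenyl in place of 3-methylphenyl gave a 1.2-fold lower number from compound 2 to compound 4 (0.08 log units; within the scatter). Compound 3 gives > 100000 nM, which is a limit of the assay and not a number. The change thus shows a step beyond the scatter on the core of compound 3, but this does not show that it acts differently on the two cores: the same change on two cores in this assay, a 1.5-fold lower number (0.18 log units; within the scatter) from compound 1 to compound 2 and an at least 2.2-fold lower number (0.35 log units; beyond the scatter) from compound 3 to compound 4; the limit leaves it open whether they differ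

The compounds shown leave open how far compound 3 truly lies from compound 4. They also leave open how a propyloxy chain, an amine or a carboxylic acid on the same aromatic carbon would read in this assay.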